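Oral exposure across the amine substituent series

The compounds below may be only part of what the source reports. "The series", "measured", "known", "first", "only" and "open" are said of these compounds alone.

Two compounds of the shared core carry measured oral exposure data. Compound 2 `CON[C@]1(CCC(C)C)C(=O)C(C2=NS(=O)(=O)c3cc(NS(C)(=O)=O)ccc3N2)=C(O)c2ccccc21` stands highest of the two in an in vivo ADME assay on the whole organism (strain Sprague-Dawley) for pharmacokinetics, with Rattus norvegicus as the target, at a dose of 5 mg/kg by the oral route (on this read-out higher numbers stand for higher oral bioavailability and lower numbers for lower oral bioavailability), where compound 2 gives 34.1%. The nearest number comes from compound 1 `Cc1ccc(CNC2(CCC(C)(C)C)C(=O)C(C3=NS(=O)(=O)c4cc(NS(C)(=O)=O)ccc4N3)=C(O)c3ccccc32)cn1`, which in this assay gives 0%, a gap beyond the usual scatter. Going by the values given here, no single-point step between these two measured compounds exists, since compound 1 and compound 2 differ at more than one place.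

Compound 3 `CC(C)CC[C@@]1(NCc2ccccc2)C(=O)C(C2=NS(=O)(=O)c3cc(NS(C)(=O)=O)ccc3N2)=C(O)c2ccccc21` is the next candidate for this assay. The change from compound 2 to compound 3 reads (benzyl in place of methoxy on an amine nitrogen), in words benzyl in place of methoxy on an amine nitrogen. Among the compounds with values here, with no measured step of this kind available, the expectation rests on the fact that compound 1, which also carries an arylmethyl group on that nitrogen, gives 0%. The step from compound 2 to compound 3 is therefore expected to be downward and beyond the scatter, as a number 26.1 percentage points lower from compound 2 to compound 3 (beyond the scatter). Compound 3 is estimated at 8%, with a range from 0% to 25%.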

Compound 3, oral bioavailability: 13.3%
Compound 3: middle estimate off by 5.3 percentage points, on the low side, and the stated range covers the measured number.
By their numbers in this assay, from the lowest: compound 1; then compound 3; then compound 2.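

In this assay the series now has its first comparison that differs in one place: a number 20.8 percentage points lower from compound 2 to compound 3 (beyond the scatter), with benzyl in place of methoxy on an amine nitrogen whose other neighbour is a saturated ring carbon. This shows that the group on this nitrogen can by itself move oral bioavailability beyond the usual scatter, while the methoxyamino to benzylamino change leaves a measurable level of oral exposure, with compound 3 at 13.3%. The data shown contain no measurement that accounts for this step, so its origin remains unassigned.

A single pair cannot separate the contribution of the departing methoxy from that of the entering benzyl, and an ethoxy or a plain methyl group on this nitrogen would help to show which side of the change carries the step. Going by these compounds, it also remains open whether the same step would appear with a different chain on the saturated ring carbon, such as a longer straight alkyl chain, in place of the chain shared by compound 2 and compound 3.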